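A few compounds are considered here, and "the series" means these few. Any claim that something is new, unique, unknown or untested is made for them only; others in the source may bear on it.

Working notes on the series. Compound 1 `O=c1ccoc(/C=C/c2ccccc2)c1` gives 514 uM in a functional assay on NCI/ADR cells (Homo sapiens) for inhibition, read by sulforhodamine B assay, with a stated time of 48 h; a lower number here means a stronger inhibitor of growth, a higher number a weaker inhibitor of growth. Compound 2 `COc1ccc(/C=C/c2cc(=O)cco2)cc1` gives 310 uM in this assay; the change from compound 1 is methoxy in place of hydrogen on an aromatic carbon and the step is a 1.7-fold lower number from compound 1 to compound 2 (0.22 log units; within the scatter). Compound 3 `COc1cc(/C=C/C2CC=CC(=O)N2)cc(OC)c1` sits on another core and gives 203 uM in this assay; the difference between the two cores is not broken down here. Compound 4 `COc1cc(/C=C/C2CC=CC(=O)N2)cc(OC)c1OC` awaits measurement. Its change from compound 3 is methoxy in place of hydrogen on an aromatic carbon, the same kind of change as from compound 1 to compound 2, though here the place is also ortho to two methoxy groups. The step expected is a 1.5-fold lower number from compound 3 to compound 4 (0.16 log units; within the scatter), set beside the earlier 1.7-fold lower number from compound 1 to compound 2 (0.22 log units; within the scatter), and it rests on that one step alone. Compound 4 is accordingly estimated at 140 uM, with a span from 55 uM to 400 uM.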

Compound 4, concentration for growth inhibition (reported as GI): > 864 uM
Compound 4 ended at the assay's limit (the forecaster's own chance of this, stated with the estimate: 5%); middle value at least 6.1-fold (0.79 log units) from the limit.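

In this assay, methoxy in place of hydrogen on an aromatic carbon gives an at least 4.2-fold higher number from compound 3 to compound 4 (0.62 log units; beyond the scatter), and the step seen on one core does not carry over to the other: the same change on two cores in this assay, a 1.7-fold lower number (0.22 log units; within the scatter) from compound 1 to compound 2 and an at least 4.2-fold higher number (0.62 log units; beyond the scatter) from compound 3 to compound 4, at least 7.0-fold (0.84 log units) apart, beyond the scatter of two such steps. For compound 4, > 864 uM is a limit of the assay and not a number: the limit of > 864 uM in this assay, at which 1 of the 4 values shown sits. With one pair per core and the methoxy of compound 4 placed ortho to two methoxy groups, these data do not show whether the core or the place accounts for the difference.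

Open, going by these compounds, is whether a methoxy on the core of compound 3 gives the same step without the two methoxy groups already on the ring. Also open, on these data alone, is how an amine or a hydroxyl at this place would read on either core.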